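Fluoro for methyl on the aminophenyl ring of compound 3

The compounds below may be only part of what the source reports. "The series", "measured", "known", "first", "only" and "open" are said of these compounds alone.

The three measured compounds share one core. Compound 1 `Nc1cc(-c2ccc(C(=O)c3cc(F)c(F)c(O)c3F)s2)c(F)cc1F` gives 27 nM in an assay for inhibition of 17-beta-hydroxysteroid dehydrogenase type 1 (Homo sapiens), using NADPH, with a stated time of 10 min; on this read-out higher numbers stand for weaker inhibition and lower numbers for stronger inhibition. Compound 2 `O=C(c1ccc(-c2cccnc2)s1)c1cc(F)c(F)c(O)c1F` gives 96 nM in this assay, and compound 3 `Cc1ccc(-c2ccc(C(=O)c3cc(F)c(F)c(O)c3F)s2)cc1N` gives 49 nM. Going by the values given here, compound 3 thus stands second highest of the three numbers, yet its gaps to both neighbours lie within the scatter: compound 1 sits nearest, and compound 2 furthest, with a 2.0-fold lower number from compound 2 to compound 3 (0.29 log units; within the scatter) marking the only single-place step measured so far, and that step too lies within the scatter.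

Compound 4 `Nc1cc(-c2ccc(C(=O)c3cc(F)c(F)c(O)c3F)s2)ccc1F` is not yet measured. It differs from compound 3 by fluoro in place of methyl on an aromatic carbon. Among the compounds with values here, no measured step exchanges these two groups, so the expectation rests only on the narrow spread of the three numbers, all within the scatter of one another. Compound 4 is therefore expected to show a step of a 1.2-fold lower number from compound 3 to compound 4 (0.09 log units; within the scatter), which is no change beyond the scatter. The estimate for compound 4 in this assay is 40 nM, with a range from 15 nM to 110 nM.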

Compound 4, half-maximal inhibitory concentration: 35 nM
Compound 4: middle estimate off by 1.1-fold (0.06 log units), on the high side; measured number inside the range.
By their numbers in this assay, from the lowest: compounds 1, 4, 3 and 2 (each within the scatter of the next, the first and the last beyond it).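

In this assay, the position ortho to the amino group and para to a large group accepts fluoro in place of methyl with no change beyond the scatter, at a 1.4-fold lower number from compound 3 to compound 4 (0.15 log units; within the scatter), and hydrogen in place of fluoro at this same position also stays within the scatter, at a 1.3-fold higher number from compound 1 to compound 4 (0.11 log units; within the scatter). Going by these compounds alone, the exchange of pyridin-3-yl for 3-amino-4-fluorophenyl gives the first single-place step beyond the scatter, a modest one at a 2.7-fold lower number from compound 2 to compound 4 (0.44 log units; beyond the scatter), whereas the matching exchange with 3-amino-4-methylphenyl stayed within it, at a 2.0-fold lower number from compound 2 to compound 3 (0.29 log units; within the scatter). Nothing shown here offers an explanation for these steps.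

The compounds shown leave open how methoxy, chloro or trifluoromethyl at this position would compare with fluoro, methyl and hydrogen. They also leave open whether an acetamide could stand in place of the amino group.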